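The source may hold more compounds than are shown below. What is called first, only, known or untested is meant among the compounds shown, and "the series" means these compounds.

Compound 1 `COc1ccccc1/C=c1/[nH]c(=O)/c(=C\c2ccccc2OC)n(C)c1=O` is the starting point. In a functional assay on HeLa cells (Homo sapiens) for cytotoxicity, read by CCK-8 assay, with a stated time of 72 h (a higher number here means a weaker inhibitor, a lower number a stronger inhibitor), compound 1 gives "not active" (no number reported), so no single number marks where it stands. Compound 4 `COc1ccccc1/C=c1\c(=O)[nH]/c(=C/c2cccc(Cl)c2Cl)c(=O)n1C` differs from it by 2,3-dichlorophenyl in place of 2-methoxyphenyl on a double-bonded chain carbon bound to an aromatic carbon. Among the compounds with values here, no measured step matches this change directly. The nearest comparison comes from compound 2 `C=CCn1c(=O)/c(=C\c2ccccc2OC)[nH]c(=O)/c1=C\c1ccccc1OC`, which in this assay gives 6900 nM, and compound 3 `C=CCn1c(=O)/c(=C\c2ccccc2C(F)(F)F)[nH]c(=O)/c1=C\c1ccccc1OC`, which in this assay gives 4600 nM. The step of a 1.5-fold lower number from compound 2 to compound 3 (0.18 log units; within the scatter) also replaces a methoxy group on an aromatic carbon, and it stayed within the scatter. Replacing the methoxy-bearing ring is therefore expected to shift the number little, and compound 4 is estimated to sit near 15000 nM, between 4000 nM and 60000 nM, with a real chance that again no number is obtained.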

Compound 4, half-maximal inhibitory concentration: 200 nM
Beside the measured number, compound 4's estimate is 75-fold (1.88 log units) above it, and the stated range ends above it.
By their numbers in this assay, from the lowest: compound 4; then compounds 3 and 2 (each within the scatter of the next).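

Within the data shown here, no step from compound 1 to compound 4 can be read: compound 1 has no single number in this assay to set against it. No measurement shown accounts for the value of compound 4. The compounds shown leave open whether both chlorine atoms of the 2,3-dichlorophenyl group, or only one, go with that value.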